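This account rests on a few compounds, and the source may have more. Where it says the series, first, only, none or still open, it means among the compounds named here.

Working notes on the series. Compound 3 `COc1cccc(Cn2ccc3nc(-c4ccccc4)nc-3c2)c1` in an ADME assay on MDBK cells (Bos taurus) for cytotoxicity (a higher number here means that more compound is tolerated, a lower number that less compound is tolerated), gives > 100000 nM, which is a limit of the assay and not a number. Compound 1 `Fc1cccc(F)c1Cn1c(-c2c(F)cccc2F)nc2ccncc21` gives 99000 nM in this assay. Compound 2 `Fc1cccc(F)c1-c1nc2ccn(Cc3ccccc3)cc-2n1` gives > 100000 nM, again a limit of the assay rather than a number. So compound 3 sits where most of the series sits, at the upper end of what this assay can report, and no change between measured compounds is available from which to read a trend.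

Compound 4 `CC(C)CCn1ccc2nc(-c3ccccc3)nc-2c1` differs from compound 3 by isobutyl in place of 3-methoxyphenyl on a saturated chain carbon bound to an aromatic nitrogen.

For compound 4 the step expected in this assay an at least 1.1-fold lower number from compound 3 to compound 4 (0.04 log units; that floor lies within the scatter) is none beyond the scatter, because of the limit of > 100000 nM in this assay, at which 2 of the 3 values shown sit. Compound 4 is estimated at 90000 nM, in a range from 40000 nM to 100000 nM, with a fair chance that only a limit is reported.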

Compound 4, half-maximal cytotoxic concentration: > 100000 nM
Compound 4 ended at the assay's limit; the forecaster's own chance of this, stated with the estimate: 50%; middle value at least 1.1-fold (0.04 log units) away from the limit.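

Going by these compounds alone, no step from compound 3 to compound 4 can be read in this assay, as both values are limits of the assay: the limit of > 100000 nM in this assay, at which 3 of the 4 values shown sit. Whether isobutyl in place of 3-methoxyphenyl changes the read-out at all stays open with the compounds shown.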